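Swapping a Trifluoromethyl for Chlorine on the Side-Chain Ring

This account rests on a few compounds, and the source may have more. Where it says the series, first, only, none or still open, it means among the compounds named here.

Going by the values given here, compound 2 `O=C(O)c1csc([C@H]2CC[C@@H]3[C@@H](COc4ccccc4C(F)(F)F)[C@H](O)C[C@@H]3O2)n1` gives 0.5 nM in a functional assay on CHO cells for agonist activity at prostaglandin E2 receptor EP2 subtype (Homo sapiens), read by HTRF and cAMP accumulation, with a stated time of 30 min (on this read-out lower numbers stand for an effect already at smaller amounts and higher numbers for an effect only at larger amounts of compound), the lowest of the two numbers so far, with compound 1 `O=C(O)c1csc([C@H]2CC[C@@H]3[C@@H](COc4cccc(Cl)c4)[C@H](O)C[C@@H]3O2)n1` giving 6.5 nM. Compound 3 `O=C(O)c1csc([C@H]2CC[C@@H]3[C@@H](COc4ccccc4Cl)[C@H](O)C[C@@H]3O2)n1` differs from compound 2 by chloro in place of trifluoromethyl on an aromatic carbon. Among the compounds with values here, the only measured step, a 13-fold lower number from compound 1 to compound 2 (1.11 log units; beyond the scatter), changed both the group and its position, so it bears on this change only loosely. Compound 3 is therefore expected to give 1.5 nM, with a range of 0.5 nM to 5 nM, a modest step of a 3.0-fold higher number from compound 2 to compound 3 (0.48 log units; beyond the scatter) toward a higher number.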

Compound 3, half-maximal effective concentration: 3.3 nM
The estimate for compound 3 lay 2.2-fold (0.34 log units) below the measured number; the range from low to high includes it.
By their numbers in this assay, from the lowest: compound 2; then compounds 3 and 1 (each within the scatter of the next).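

With the place on the ring held fixed, the group alone matters in this assay: 2-chlorophenyl in place of 2-(trifluoromethyl)phenyl gives a 6.6-fold higher number from compound 2 to compound 3 (0.82 log units; beyond the scatter). Moving the chlorine, by contrast, gives a 2.0-fold lower number from compound 1 to compound 3 (0.29 log units; within the scatter), so 3-chlorophenyl and 2-chlorophenyl cannot be told apart here. Nothing available explains the advantage of trifluoromethyl over chloro.

As far as these compounds go, it remains open whether a methoxy, a nitrile or an amine at this place would match trifluoromethyl. From the compounds shown here alone, it also remains open whether trifluoromethyl would keep its advantage at the place the chlorine holds in 3-chlorophenyl.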